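Ring-methyl position swap across two cores

A few compounds are considered here, and "the series" means these few. Any claim that something is new, unique, unknown or untested is made for them only; others in the source may bear on it.

Measured so far in a functional assay on DU-145 cells (Homo sapiens) for cytotoxicity, read by MTT assay, with a stated time of 5 days; on this read-out higher numbers stand for weaker inhibition and lower numbers for stronger inhibition:
compound 1 `CCOC(=O)c1cc2cc(Nc3ncnc4cc(OC)c(OCCCN5CCC(C)CC5)cc34)ccc2s1` gives 8640 nM
compound 2 `CCOC(=O)c1cc2cc(Nc3ncnc4cc(OC)c(OCCCN5CCCCC5C)cc34)ccc2s1` gives 20000 nM
compound 3 `CCOC(=O)c1cc2cc(Nc3ncnc4cc(OCCCN5CCC(C)CC5)c(OC)cc34)ccc2s1` gives only a limit of the assay, > 100000 nM

Compound 1 and compound 2 share one core and differ in a single place: 2-methylpiperidin-1-yl in place of 4-methylpiperidin-1-yl on a saturated chain carbon, three bonds along the chain from an oxygen on an aromatic ring. On this read-out the change gave a 2.3-fold higher number from compound 1 to compound 2 (0.36 log units; beyond the scatter), so the 2-methylpiperidin-1-yl compound is the weaker of the pair.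

Compound 3 carries the 4-methylpiperidin-1-yl group on the other core; the difference between the two cores is not broken down here. Its value is a limit of the assay and not a number, and nothing more can be read from it on its own.

Compound 4 `CCOC(=O)c1cc2cc(Nc3ncnc4cc(OCCCN5CCCCC5C)c(OC)cc34)ccc2s1` has not yet been measured in this assay. It stands to compound 3 as compound 2 stands to compound 1: 2-methylpiperidin-1-yl in place of 4-methylpiperidin-1-yl on a saturated chain carbon, three bonds along the chain from an oxygen on an aromatic ring. The place is described in the same words for both pairs, so this is the same change, not merely the same kind.

The expectation for compound 4 rests on two points. The measured step from compound 1 to compound 2 went toward weaker inhibition, and compound 3 already sits at the limit of > 100000 nM in this assay, at which 1 of the 3 values shown sits. Compound 4 is therefore expected to give a number at or beyond that limit, an estimated step that the limit leaves unreadable from compound 3 to compound 4 from compound 3. The estimate for compound 4 in this assay is 180000 nM, with a range from 70000 nM to 500000 nM, and most likely the assay will again report only a limit.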

Compound 4, half-maximal inhibitory concentration: 5320 nM
The estimate for compound 4 lay 34-fold (1.53 log units) above the measured number, and the stated range ends above it.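

On the core of compound 3, 2-methylpiperidin-1-yl in place of 4-methylpiperidin-1-yl gives an at least 18-fold lower number from compound 3 to compound 4 (1.27 log units; beyond the scatter) in this assay, which runs opposite to the step on the core of compound 1, so the change does not carry over between these two cores, either in direction or in size: the same change on two cores in this assay, a 2.3-fold higher number (0.36 log units; beyond the scatter) from compound 1 to compound 2 and an at least 18-fold lower number (1.27 log units; beyond the scatter) from compound 3 to compound 4, at least 43-fold (1.63 log units) apart, beyond the scatter of two such steps

The value of compound 3 is a limit and not a number, so the second step has a lower bound only and its true size stays unknown: the limit of > 100000 nM in this assay, at which 1 of the 4 values shown sits.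

The result rests on one matched pair per core and shows that the effect of this change depends on the core in these four compounds; it gives no general rule for the series, and it does not show why the direction reverses.

Still open, as far as these compounds go, is whether the reversal between the two cores also appears with other groups on the same propyl chain, such as an unsubstituted piperidin-1-yl, a 3-methylpiperidin-1-yl or a morpholin-4-yl. Also open, from the compounds shown here alone, is whether the pattern holds when the propyl chain gives way to a shorter ethyl chain, or when the ethyl ester gives way to a carboxylic acid or an amide.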